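This account rests on a few compounds, and the source may have more. Where it says the series, first, only, none or still open, it means among the compounds named here.

Measured so far:

compound 1 `O=C(CCN1C(=O)CSc2ccccc21)N1CCN(c2ccccc2F)CC1`: > 100000 nM in a functional assay (MiaPaCa cells, Homo sapiens) for inhibition, read by sulforhodamine B assay, with a stated time of 48 h; a higher number here means a weaker inhibitor of growth, a lower number a stronger inhibitor of growth
compound 2 `COc1ccccc1N1CCN(CCCNC(=O)CCN2C(=O)CSc3ccccc32)CC1`: 59200 nM in this assay

The value for compound 1 is a limit of the assay and not a number (the limit of > 100000 nM in this assay, at which 1 of the 2 values shown sits). Among the measured compounds shown here, compound 2 therefore stands alone as the only numerical result in this assay; the other entry is a limit, so no measured step within the set can be drawn.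

The step followed here goes from compound 2 to compound 3 `O=C(CCN1C(=O)CSc2ccccc21)NCCCN1CCN(c2ccccc2)CC1`, which is still to be tested in this assay. The change is hydrogen in place of methoxy on an aromatic carbon. For the measured compounds named here, no measured pair makes this same change, so the size of the step cannot be read from existing data. With compound 2 at 59200 nM, the expectation is for a step that stays close to the scatter, if anything toward weaker inhibition of growth. The expected value for compound 3 is 70000 nM, within 30000 nM to 160000 nM. The step this estimate implies is a 1.2-fold higher number from compound 2 to compound 3 (0.07 log units; within the scatter).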

Compound 3, concentration for 50% growth inhibition: > 100000 nM
Compound 3: a limit, no number (the forecaster's own chance of this, stated with the estimate: 35%); middle value at least 1.4-fold (0.15 log units) away from the limit.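

In this assay compound 3 gives > 100000 nM, which is a limit of the assay and not a number. The change from 2-methoxyphenyl to phenyl gives the first step that can be read in this series, an at least 1.6-fold higher number from compound 2 to compound 3 (0.22 log units; that floor lies within the scatter); it is one-sided, so removing the methoxy group brings no gain in growth inhibition, while a loss beyond the scatter is neither shown nor ruled out. Compound 2 remains the only compound with a number, and the rest of the series sits at the edge of the read-out: the limit of > 100000 nM in this assay, at which 2 of the 3 values shown sit.

As far as these compounds go, how far compound 3 actually lies from compound 2 stays open, and so does the question of whether methoxy at this position matters at all, since the whole comparison rests on one weak number and one limit. Also open, from the compounds shown here alone, is whether a hydroxyl group or a chlorine atom on this aromatic carbon, or a longer chain in the linker, would give a clearly stronger inhibitor of growth in this assay.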